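Removing the benzyl on nitrogen in a weak aortic inhibitor

This account rests on a few compounds, and the source may have more. Where it says the series, first, only, none or still open, it means among the compounds named here.

Compound 1, `O=c1ccc(CCOCc2ccccc2)nn1Cc1ccccc1`, gives 32300 nM in a functional assay on aorta (Rattus norvegicus); a lower number here means a stronger inhibitor, a higher number a weaker inhibitor. Compound 2, `O=c1ccc(CCO)nn1Cc1ccccc1`, reaches only a limit of > 100000 nM in this assay.

Going by the values given here, compound 1 thus stands as the only plain number in this assay; the other result is a limit (the limit of > 100000 nM in this assay, at which 1 of the 2 values shown sits). Compound 3, `Cn1nc(CCOCc2ccccc2)ccc1=O`, differs from compound 1 by hydrogen in place of phenyl on a saturated chain carbon bound to an aromatic nitrogen. Among the compounds with values here, the one measured step, an at least 3.0-fold higher number from compound 1 to compound 2 (0.49 log units; beyond the scatter), sits at the oxygen, not at the nitrogen, so it bears only loosely on this change. A step of a 1.9-fold higher number from compound 1 to compound 3 (0.27 log units; within the scatter) toward a weaker inhibitor in this assay is expected, with wide uncertainty. Compound 3 is estimated at 60000 nM, between 20000 nM and 200000 nM.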

Compound 3, half-maximal inhibitory concentration: > 100000 nM
Compound 3: only a limit was reported; the forecaster's own chance of this, stated with the estimate: 45%; middle value at least 1.6-fold (0.22 log units) away from the limit.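

Changing benzyl to methyl on the nitrogen gives an at least 3.0-fold higher number from compound 1 to compound 3 (0.49 log units; beyond the scatter), so this position, like the oxygen, bears on the result in this assay. Compound 3 gives only a limit, so the full size of this step cannot be read. With methyl on this nitrogen or hydrogen on the oxygen, the result ends at one limit: the limit of > 100000 nM in this assay, at which 2 of the 3 values shown sit.

Going by these compounds, what stays open is whether the phenyl ring itself counts or only the size of the group. An ethyl, a cyclohexylmethyl or a chlorobenzyl group on this nitrogen would bear on that question.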